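A Methylene Inserted Between Ring and Ester

The compounds below may be only part of what the source reports. "The series", "measured", "known", "first", "only" and "open" are said of these compounds alone.

Compound 1, `CCCCCCOc1cc(C(C)(C)C)ccc1C/N=C(\S)NCc1ccc(NS(C)(=O)=O)cc1`, gives 150 nM in a functional assay for inhibition of Vanilloid receptor (Rattus norvegicus); on this read-out lower numbers stand for stronger inhibition and higher numbers for weaker inhibition. Compound 2, `CC(C)(C)c1ccc(C/N=C(\S)NCc2ccc(NS(C)(=O)=O)cc2)c(OCc2ccccc2)c1`, gives 770 nM in this assay. Compound 3, `CC(C)(C)C(=O)Oc1cc(C(C)(C)C)ccc1C/N=C(\S)NCc1ccc(NS(C)(=O)=O)cc1`, gives 220 nM in this assay.

Compound 3 stands second highest of these three numbers; compound 1 lies within the scatter of it, compound 2 beyond it. Compound 4, `CC(C)(C)C(=O)OCc1cc(C(C)(C)C)ccc1C/N=C(\S)NCc1ccc(NS(C)(=O)=O)cc1`, differs from compound 3 by (((tert-butyl)carbonyl)oxy)methyl in place of ((tert-butyl)carbonyl)oxy on an aromatic carbon. For the measured compounds named here, no measured step inserts a carbon in this way. The steps touching the same position are a 1.5-fold higher number from compound 1 to compound 3 (0.17 log units; within the scatter) and a 3.5-fold lower number from compound 2 to compound 3 (0.54 log units; beyond the scatter), while a 5.1-fold higher number from compound 1 to compound 2 (0.71 log units; beyond the scatter) swaps groups further out. Because a 1.5-fold higher number from compound 1 to compound 3 (0.17 log units; within the scatter) stayed within the scatter and the larger swaps stayed modest, the step of a 1.3-fold higher number from compound 3 to compound 4 (0.10 log units; within the scatter) is expected to be small, if anything toward a slightly higher number. Compound 4 is therefore estimated at 280 nM, with a range from 110 nM to 750 nM.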

Compound 4, half-maximal inhibitory concentration: 70 nM
Beside the measured number, compound 4's estimate is 4.0-fold (0.60 log units) above it; measured number outside the range, below it.
By their numbers in this assay, from the lowest: compound 4; then compounds 1 and 3 (each within the scatter of the next); then compound 2.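

At this position the length of the link counts, not only the group at its end: with the same (tert-butyl)carbonyl group kept, the added methylene gives a 3.1-fold lower number from compound 3 to compound 4 (0.50 log units; beyond the scatter). Compound 4 also has the lowest number of the four, with a 2.1-fold lower number from compound 1 to compound 4 (0.33 log units; beyond the scatter) and an 11-fold lower number from compound 2 to compound 4 (1.04 log units; beyond the scatter). No measurement shown accounts for these steps.

Going by these compounds, whether a longer chain carrying the same ester would keep this lower number stays open. So does the outcome with an amine or a carboxylic acid on that methylene.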